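Replacing diethylamino in compound 2: an estimate for compound 3

A few compounds are considered here, and "the series" means these few. Any claim that something is new, unique, unknown or untested is made for them only; others in the source may bear on it.

Compound 1 `COc1cc(N2CCC(CC(=O)N3CCN(C)CC3)CC2)ccc1Nc1nc(NC2CCCCC2)c2nc[nH]c2n1` reads 38000 nM
Compound 2 `CCN(CC)CC1CCN(c2ccc(Nc3nc(NC4CCCCC4)c4nc[nH]c4n3)c(OC)c2)CC1` reads 19000 nM

Among the measured compounds shown here, both numbers come from a physicochemical assay for solubility, measured as kinetic solubility, at pH 7.4 (on this read-out lower numbers stand for lower solubility and higher numbers for higher solubility), and they lie within the scatter of each other, so compound 2 stands level with the only other compound measured so far. Compound 3 `COc1cc(N2CCC(CC(=O)N3CCC(N(C)C)C3)CC2)ccc1Nc1nc(NC2CCCCC2)c2nc[nH]c2n1` departs from compound 2 in one place (3-(dimethylamino)pyrrolidin-1-yl)carbonyl in place of diethylamino on a saturated chain carbon bound to a saturated ring carbon where (3-(dimethylamino)pyrrolidin-1-yl)carbonyl takes the place of diethylamino on a saturated chain carbon bound to a saturated ring carbon. Compound 1 carries (4-methylpiperazin-1-yl)carbonyl on that same carbon, so compound 3 resembles compound 1 there. For the measured compounds named here, the one measured step that bears on this is a 2.0-fold lower number from compound 1 to compound 2 (0.30 log units; within the scatter) and it swaps diethylamino for that related carbonyl group. Since that step stays within the scatter, a step of similar size is expected here, with at most a slight drift toward the number of compound 1. The expected step is a 1.6-fold higher number from compound 2 to compound 3 (0.20 log units; within the scatter) and nothing beyond the scatter is anticipated. A single step is thin evidence, so the range is kept wide. The estimate for compound 3 is 30000 nM with an expected range from 13000 nM to 70000 nM in this assay once it is measured.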

Compound 3, solubility: 75000 nM
Beside the measured number, compound 3's estimate is 2.5-fold (0.40 log units) below it, outside the stated range (above it).
By their numbers in this assay, from the lowest: compounds 2, 1 and 3 (each within the scatter of the next, the first and the last beyond it).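

In this assay, among the compounds shown here, putting (3-(dimethylamino)pyrrolidin-1-yl)carbonyl in place of diethylamino on a saturated chain carbon bound to a saturated ring carbon gives a 3.9-fold higher number from compound 2 to compound 3 (0.60 log units; beyond the scatter), the first change at this position that goes beyond the scatter of the measurement. Changing only the group on the carbonyl carbon, with 3-(dimethylamino)pyrrolidin-1-yl in place of 4-methylpiperazin-1-yl, gives a 2.0-fold higher number from compound 1 to compound 3 (0.30 log units; within the scatter), so a clear separation appears only between compound 2 and compound 3, while compound 1 stays within the scatter of both. No supporting evidence is available to explain this separation.

Compound 3 brings a carbonyl and a five-membered ring into this place together, so the compounds shown leave open which of the two goes with the higher number, or whether it takes both. Also open, from the compounds shown here alone, is how a carboxylic acid, a morpholin-4-ylcarbonyl group or a longer chain ending in diethylamino would read on the same saturated chain carbon, with the rest of the molecule unchanged.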